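Trifluoromethyl to Cyano: Predicting Compound 4

The compounds below may be only part of what the source reports. "The series", "measured", "known", "first", "only" and "open" are said of these compounds alone.

Of the compounds shown here, three built on one shared amide core have been measured in an assay on membranes from brain for binding affinity to metabotropic glutamate receptor 5 (Rattus norvegicus); a higher number here means a weaker inhibitor, a lower number a stronger inhibitor. Compound 1 `Cc1cccc(NC(=O)c2ccccc2)n1` gives 35000 nM. Compound 2 `O=C(Nc1ccccn1)c1ccccc1` gives 95400 nM; taking away the methyl brings a 2.7-fold higher number from compound 1 to compound 2 (0.44 log units; beyond the scatter). Compound 3 `Cc1cccc(NC(=O)c2cccc(C(F)(F)F)c2)n1` gives 18700 nM, the lowest of the three numbers. Putting trifluoromethyl onto the core of compound 1 brings a 1.9-fold lower number from compound 1 to compound 3 (0.27 log units; within the scatter), so compound 3 cannot be called a stronger inhibitor than compound 1 on these numbers, although it stands clearly apart from compound 2.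

Compound 4 `Cc1cccc(NC(=O)c2cccc(C#N)c2)n1` has not yet been measured in this assay. It differs from compound 3 in one place: cyano in place of trifluoromethyl on an aromatic carbon. Among the compounds with values here, no measured pair makes this exact exchange. Within the data shown here, the only measured step at that position is the one that introduced trifluoromethyl, and that step stayed within the scatter. With so little to go on, the expectation is that the exchange moves the number only slightly, if at all, and the estimated step is a 1.4-fold lower number from compound 3 to compound 4 (0.16 log units; within the scatter). Compound 4 is therefore expected to give about 13000 nM in this assay, with a likely range from 4000 nM to 45000 nM.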

Compound 4, half-maximal inhibitory concentration: 330 nM
Compound 4: the middle estimate sits 39-fold (1.60 log units) above what was measured; measured number outside the range, below it.
By their numbers in this assay, from the lowest: compound 4; then compounds 3 and 1 (each within the scatter of the next); then compound 2.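

In this assay, the aromatic carbon that carries trifluoromethyl in compound 3 proves highly sensitive to which group sits there: exchanging that group for cyano brings a 57-fold lower number from compound 3 to compound 4 (1.75 log units; beyond the scatter) and so moves the number far beyond the scatter. The earlier compounds shown here gave no sign of this, since trifluoromethyl in place of hydrogen had stayed within the scatter, whereas cyano in place of hydrogen brings a 110-fold lower number from compound 1 to compound 4 (2.03 log units; beyond the scatter) and shows that a group at this position can change the number greatly. Nothing in the available data explains why cyano and trifluoromethyl differ so widely here.

The compounds shown cover only hydrogen, trifluoromethyl and cyano at this position, so they leave open whether another group, such as an amine, a carboxylic acid or a methoxy group, would give a number as low as that of compound 4. They also leave open whether cyano would bring a similarly large step on the core of compound 2, which carries hydrogen in place of the methyl, or at another aromatic carbon of the shared core.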